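Swapping a Trifluoroethoxy Group for Methylpiperazine

A few compounds are considered here, and "the series" means these few. Any claim that something is new, unique, unknown or untested is made for them only; others in the source may bear on it.

Of the compounds shown here, two sharing one core have been measured in an assay on isolated protein for inhibition of Ectonucleotide pyrophosphatase/phosphodiesterase family member 1 (Homo sapiens), tested at 10 uM; on this read-out higher numbers stand for more inhibition at the one concentration tested (going by the name of the read-out) and lower numbers for less inhibition. Compound 1 `COc1cccc(NC(=O)CSc2nc3cccnc3[nH]2)c1` gives 30% in this assay. Compound 2 `COc1ccc(NC(=O)CSc2nc3ccc(OCC(F)(F)F)nc3[nH]2)cc1OC` gives 61%, the higher of the two numbers, and the value of compound 1 sits well below it, farther apart than repeated measurements usually scatter. The two compounds differ in more than one place, so their gap cannot be tied to a single change.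

Compound 3 `COc1ccc(NC(=O)CSc2nc3ccc(N4CCN(C)CC4)nc3[nH]2)cc1OC` is a close relative of compound 2, altered in just one spot: 4-methylpiperazin-1-yl in place of 2,2,2-trifluoroethoxy on an aromatic carbon. Among the compounds with values here, nothing measured so far shows how this kind of swap moves the numbers, so the expected step of a number 11 percentage points lower from compound 2 to compound 3 (beyond the scatter) is small, within the usual scatter, and its direction is open. On that basis compound 3 is estimated to give about 50% in this assay, plausibly anywhere between 25% and 75%.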

Compound 3, a percentage reported as inhibition, at one concentration (the size of the read-out at that concentration, not a potency): 35%
The estimate for compound 3 lay 15 percentage points above the measured number; the range from low to high includes it.
By their numbers in this assay, from the lowest: compounds 1 and 3 (each within the scatter of the next); then compound 2.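

Within the data shown here, this pair gives the first reading of a single change at this spot, the aromatic carbon next to the ring nitrogen: in this assay, 4-methylpiperazin-1-yl in place of 2,2,2-trifluoroethoxy gives a number 26 percentage points lower from compound 2 to compound 3 (beyond the scatter) and so leaves less inhibition at the one concentration tested. The position is therefore not indifferent to what sits on it, at least for these two groups, which differ in having a ring or none and in their atoms. No measurement at hand accounts for the difference.

A single swap cannot show whether the oxygen link, the fluorine atoms or the piperazine ring matters most. A plain ethoxy group or a morpholine ring on this carbon, with the rest of compound 2 unchanged, would help to pull those features apart.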